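A few compounds are considered here, and "the series" means these few. Any claim that something is new, unique, unknown or untested is made for them only; others in the source may bear on it.

Series notes. Within the data shown here, compound 1 `Cc1c(C(=O)Nc2ccc(Oc3ccnc4[nH]ccc34)c(F)c2)nnn1-c1ccccc1F` is the first member with a methyl group on the shared core; in a functional assay on HT-29 cells (Homo sapiens) for cytotoxicity, read by MTT assay, with a stated time of 72 h (a higher number here means a weaker inhibitor, a lower number a stronger inhibitor), compound 1 gives 180 nM. Compound 2 `Cc1c(C(=O)Nc2ccc(Oc3ccnc4[nH]ccc34)c(F)c2)nnn1-c1ccc(F)cc1` differs from it by 4-fluorophenyl in place of 2-fluorophenyl on an aromatic nitrogen, and in this assay compound 2 gives 120 nM, so that a 1.5-fold lower number from compound 1 to compound 2 (0.18 log units; within the scatter). Compound 3 `O=C(Nc1ccc(Oc2ccnc3[nH]ccc23)cc1)c1nnn(-c2ccccc2F)c1C(F)(F)F` carries a trifluoromethyl group on its core; the difference between the core of compound 1 and the core of compound 3 is not broken down here. In this assay compound 3 gives 120 nM, level with compound 2 at the digits read, and its two values against compound 1 lie within the scatter. Compound 4 `O=C(Nc1ccc(Oc2ccnc3[nH]ccc23)cc1)c1nnn(-c2ccc(F)cc2)c1C(F)(F)F`, not yet measured, differs from compound 3 by 4-fluorophenyl in place of 2-fluorophenyl on an aromatic nitrogen. This is the same kind of change as that from compound 1 to compound 2, not the same: there the phenyl-bearing ring nitrogen sits next to the ring atom that bears a methyl group, here next to the ring atom that bears a trifluoromethyl group. The step from compound 3 to compound 4 in this assay is expected to be a 1.3-fold lower number from compound 3 to compound 4 (0.12 log units; within the scatter), resting on the earlier pair, because a 1.5-fold lower number from compound 1 to compound 2 (0.18 log units; within the scatter) stayed within the scatter. Compound 4 is therefore estimated at 90 nM, between 45 nM and 200 nM.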

Compound 4, half-maximal inhibitory concentration: 93 nM
Estimate against measurement, compound 4: 1.0-fold (0.01 log units) below, within the range that was stated.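

In this assay, 4-fluorophenyl in place of 2-fluorophenyl on the aromatic nitrogen gives a 1.3-fold lower number from compound 3 to compound 4 (0.11 log units; within the scatter). Set beside the earlier pair, the change carries from one core to the other with no difference in size that can be told from the scatter: the same change on two cores in this assay, a 1.5-fold lower number (0.18 log units; within the scatter) from compound 1 to compound 2 and a 1.3-fold lower number (0.11 log units; within the scatter) from compound 3 to compound 4, 1.2-fold (0.07 log units) apart, within the scatter of two such steps Both steps lie within the scatter, so the result shows only that this swap leaves the number in the same range on these two cores; it shows neither a real gain from 4-fluorophenyl nor that the same would hold on a third core.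

The compounds shown leave open what other groups on that aromatic nitrogen would do, such as an unsubstituted phenyl, a phenyl carrying an amine or a longer alkyl chain in place of the ring. Also open is how methyl and trifluoromethyl compare on their own, as the compounds shown hold no pair that differs only there.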